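Piperidine methylation in a dichlorophenyl core

The compounds below may be only part of what the source reports. "The series", "measured", "known", "first", "only" and "open" are said of these compounds alone.

Measured compounds:
- compound 1, `C=CCc1cc(-c2ccc(O)c(CC=C)c2)c(O)c(C(c2ccc(Cl)cc2)N2CCCCC2)c1`: 45%
- compound 2, `C=CCc1cc(-c2ccc(O)c(CC=C)c2)c(O)c(C(c2ccc(Cl)cc2)N2CCC(C)CC2)c1`: 8.6%
- compound 3, `C=CCc1cc(-c2ccc(O)c(CC=C)c2)c(O)c(C(c2cc(Cl)cc(Cl)c2)N2CCCCC2)c1`: 87.7%

All three were run in an assay on isolated protein for inhibition of Maltase-glucoamylase (Homo sapiens), with stated times of 15 min and 10 min, tested at 64 uM; a higher number here means more inhibition at the concentration tested (going by the name of the read-out), a lower number less inhibition. The highest read-out among them belongs to compound 3, with 87.7%; compound 1 gives 45% and compound 2 gives 8.6%.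

The two cores differ by 3,5-dichlorophenyl in place of 4-chlorophenyl on a saturated chain carbon bound to an amine nitrogen in a ring and an aromatic carbon, and this change gave a number 42.7 percentage points higher from compound 1 to compound 3 (beyond the scatter). Within the core of compound 1, the change methyl in place of hydrogen on a saturated ring carbon gave a number 36.4 percentage points lower from compound 1 to compound 2 (beyond the scatter), a loss that stands well beyond the scatter.

Compound 4, `C=CCc1cc(-c2ccc(O)c(CC=C)c2)c(O)c(C(c2cc(Cl)cc(Cl)c2)N2CCC(C)CC2)c1`, is not yet measured. Among the compounds with values here, it differs from compound 3 by methyl in place of hydrogen on a saturated ring carbon, which is the same change as the one made from compound 1 to compound 2, at the same place. Within the data shown here, the only measured instance of this change is the loss seen in a number 36.4 percentage points lower from compound 1 to compound 2 (beyond the scatter), so a step of a similar size and direction is expected here as well, although a single pair cannot show whether the loss transfers unchanged onto the core of compound 3. The expected step is a number 37.7 percentage points lower from compound 3 to compound 4 (beyond the scatter) in this assay. That expectation rests on the starting point of compound 3, which gives 87.7%, and on the earlier loss a number 36.4 percentage points lower from compound 1 to compound 2 (beyond the scatter). Compound 4 is therefore estimated to give 50%, with a likely range from 25% to 78%.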

Compound 4, a percentage reported as inhibition, at one concentration (the size of the read-out at that concentration, not a potency): 97.5%
Compound 4: the middle estimate sits 47.5 percentage points below what was measured; measured number outside the range, above it.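

In this assay, methyl in place of hydrogen on a saturated ring carbon (piperidin-1-yl to 4-methylpiperidin-1-yl) does not carry over unchanged from the core of compound 1 to the core of compound 3; on the latter the step is a number 9.8 percentage points higher from compound 3 to compound 4 (within the scatter), so the earlier loss does not recur there: the same change on two cores in this assay, a number 36.4 percentage points lower (beyond the scatter) from compound 1 to compound 2 and a number 9.8 percentage points higher (within the scatter) from compound 3 to compound 4, 46.2 percentage points apart, beyond the scatter of two such steps

Read the other way, 3,5-dichlorophenyl in place of 4-chlorophenyl gives a number 88.9 percentage points higher from compound 2 to compound 4 (beyond the scatter), so the size of that step also depends on the core carrying it: the same change on two cores in this assay, a number 42.7 percentage points higher (beyond the scatter) from compound 1 to compound 3 and a number 88.9 percentage points higher (beyond the scatter) from compound 2 to compound 4, 46.2 percentage points apart, beyond the scatter of two such steps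

This shows that the two changes do not add up independently in this pair of cores, but it rests on a single set of four compounds at one concentration and does not show how the methyl would behave on any other core, nor what underlies the difference between these two.

Still open, as far as these compounds go, is whether a larger group on the same ring carbon, such as ethyl, or a hydroxyl group there would follow the pattern of the methyl on each of the two cores. Also open, from the compounds shown here alone, is whether a full concentration series would separate compound 3 from compound 4, whose read-outs at one concentration lie within the scatter of each other.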